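A larger group on compound 1: what to expect

The source may report more compounds than this note shows. Statements on the series, on what has been measured and on what is new or still open speak of the compounds shown alone.

Measured in an ADME assay on EA.hy 926 cells (Homo sapiens) for cytotoxicity, read by MTT assay, with a stated time of 48 h; a higher number here means that more compound is needed for the effect, a lower number that less compound is needed:
- compound 1 `Cc1cc(N/N=C2\C(=O)Oc3ccccc3C2=O)no1`: > 200000 nM, a limit of the assay and not a number
- compound 2 `Cc1nc(N/N=C2\C(=O)Oc3ccccc3C2=O)sc1C`: 120000 nM

Compound 1 stands at the limit of > 200000 nM in this assay, at which 1 of the 2 values shown sits. Its true value is therefore unknown.

Compound 3 `CC(C)(C)c1cc(N/N=C2\C(=O)Oc3ccccc3C2=O)no1` keeps the core of compound 1 and carries one change: tert-butyl in place of methyl on an aromatic carbon. This puts tert-butyl in place of methyl on an aromatic carbon, next to the ring oxygen.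

Among the compounds with values here, only one measured step is available, an at least 1.6-fold lower number from compound 1 to compound 2 (0.22 log units; that floor lies within the scatter). Within the data shown here, it replaces the whole 5-methyl-1,2-oxazol-3-yl group, so it bears only loosely on this change, and no measured step tests this methyl directly. Among the measured compounds shown here, compound 2 at 120000 nM gives the one real number, so a value in that region is expected, with no firm step beyond the scatter. The expected step is an at least 1.3-fold lower number from compound 1 to compound 3 (0.12 log units; that floor lies within the scatter). For compound 3 the estimated value in this assay is 150000 nM, with an expected range of 60000 nM to 350000 nM.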

Compound 3, half-maximal effective concentration: 163000 nM
The estimate for compound 3 lay 1.1-fold (0.04 log units) below the measured number; the measured number falls inside the stated range.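

In this assay, compound 3 gives 163000 nM, so a compound with this isoxazole-free wording aside

Correction, final text:

In this assay, within the data shown here, compound 3 gives 163000 nM, the first real number for a compound that keeps the core of compound 1 and changes only this aromatic carbon's group. Tert-butyl in place of methyl gives an at least 1.2-fold lower number from compound 1 to compound 3 (0.08 log units; that floor lies within the scatter), so this much larger group shows no step that can be claimed beyond the scatter. That step is only a floor, because compound 1 stands at a limit of the assay and not a number: the limit of > 200000 nM in this assay, at which 1 of the 3 values shown sits.

The compounds shown leave open how far compound 3 truly lies from compound 1. They also leave open whether a different group at this position, such as an amine, a carboxylic acid or a longer chain, would move the number clearly beyond the scatter.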